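Isopropyl for methyl on the acyl group

The source may report more compounds than this note shows. Statements on the series, on what has been measured and on what is new or still open speak of the compounds shown alone.

- compound 1 `Cc1ccc2nc([C@H](CC3CCN(C(=O)C(C)C)CC3)N3C(=O)CN(c4ccc(Oc5ccccc5)cc4)C3=O)n(C)c2c1`: > 100000 nM (a limit)
- compound 2 `CC(=O)N1CCC(C[C@@H](c2nc3ccccc3n2C)N2C(=O)CN(c3ccc(Oc4ccccc4)cc3)C2=O)CC1`: 32100 nM
- compound 3 `CC(=O)N1CCC(C[C@@H](c2nc3cc(F)ccc3n2C)N2C(=O)CN(c3ccc(Oc4ccccc4)cc3)C2=O)CC1`: > 100000 nM (a limit)
- compound 4 `CC(C)C(=O)N1CCC(C[C@@H](c2nc3ccccc3n2C)N2C(=O)CN(c3ccc(Oc4ccccc4)cc3)C2=O)CC1`: not yet measured

Going by the values given here, in a functional assay on Hep 3B2 cells (Homo sapiens) for cytotoxicity, read by MTT assay (on this read-out higher numbers stand for weaker inhibition and lower numbers for stronger inhibition), compound 2 gives 32100 nM, the only exact number. The other two measured compounds stand at the limit of > 100000 nM in this assay, at which 2 of the 3 values shown sit.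

Compound 4 differs from compound 2 by isopropyl in place of methyl on a carbonyl carbon. Among the compounds with values here, no measured step covers this change directly. Within the data shown here, the one measured step, an at least 3.1-fold higher number from compound 2 to compound 3 (0.49 log units; beyond the scatter), is fluoro in place of hydrogen on an aromatic carbon, so it bears only loosely on this change. Compound 1 also carries the isopropylcarbonyl group, but its core differs as well. Compound 1 gives > 100000 nM, which is a limit. On this thin evidence, a modest move toward a higher number, meaning weaker inhibition, is expected: a 2.2-fold higher number from compound 2 to compound 4 (0.34 log units; beyond the scatter). For compound 4 the estimated value is 70000 nM, with an expected range of 28000 nM to 100000 nM.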

Compound 4, half-maximal inhibitory concentration: > 100000 nM
Compound 4 gave a limit, no number; the forecaster's own chance of this, stated with the estimate: 45%; middle value at least 1.4-fold (0.15 log units) away from the limit.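

Isopropyl in place of methyl on a carbonyl carbon, taken alone on the shared core, gives in this assay an at least 3.1-fold higher number from compound 2 to compound 4 (0.49 log units; beyond the scatter), so this position responds to the change by itself. Compound 1 carries the same isopropylcarbonyl group on a different core and could not isolate this; the step from compound 1 to compound 4, with a limit at both ends, cannot be read. Acetyl on the unfluorinated core remains the only exact reading, and both single changes from compound 2 end at the same limit: the limit of > 100000 nM in this assay, at which 3 of the 4 values shown sit.

On these data alone, how far compound 4 lies past its limit stays unknown, so the isopropyl and fluoro steps cannot be ranked against each other. Also open, as far as these compounds go, is what ethyl or an amine-bearing chain in place of methyl on the carbonyl carbon would give in this assay.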